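The source may report more compounds than this note shows. Statements on the series, on what has been measured and on what is new or still open speak of the compounds shown alone.

Measured so far:
compound 1 `COc1ccc([C@@H]2CC(=O)c3c(O)cc(OCc4cn(Cc5ccccc5F)nn4)cc3O2)cc1O` — 7320 nM in a functional assay on RAW264.7 cells (Mus musculus) for inhibition, read by Griess assay, with stated times of 2 h and 24 h; a higher number here means a weaker inhibitor, a lower number a stronger inhibitor
compound 2 `COc1ccc([C@@H]2CC(=O)c3c(O)cc(OCc4cn(Cc5ccccc5)nn4)cc3O2)cc1O` — 11000 nM
compound 3 `C=CCn1cc(COc2cc(O)c3c(c2)O[C@H](c2ccc(OC)c(O)c2)CC3=O)nn1` — 13800 nM

Compound 3 gives the highest of the three numbers; its nearest neighbour is compound 2, the furthest compound 1, yet both gaps lie within the scatter, so no order among the three is claimed. Compound 4 `COc1ccc([C@@H]2CC(=O)c3c(O)cc(OCc4cn(C)nn4)cc3O2)cc1O` differs from compound 3 by hydrogen in place of vinyl on a saturated chain carbon bound to an aromatic nitrogen. Among the measured compounds shown here, the steps that bear on this position are a 1.3-fold higher number from compound 2 to compound 3 (0.10 log units; within the scatter) and a 1.9-fold higher number from compound 1 to compound 3 (0.28 log units; within the scatter); both exchanges on the saturated chain carbon bound to an aromatic nitrogen left the number within the scatter. The change to compound 4 is of the same kind, so no step beyond the scatter is expected in this assay. Compound 4 is expected at 14000 nM, with a range from 6000 nM to 32000 nM. The expected step is a 1.0-fold higher number from compound 3 to compound 4 (0.01 log units; within the scatter).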

Compound 4, half-maximal inhibitory concentration: 15200 nM
For compound 4 the middle estimate is 1.1-fold (0.04 log units) below the measured one; the range from low to high includes it.
By their numbers in this assay, from the lowest: compounds 1, 2, 3 and 4 (each within the scatter of the next, the first and the last beyond it).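

In this assay replacing vinyl with hydrogen on the saturated chain carbon bound to an aromatic nitrogen stays within the scatter at a 1.1-fold higher number from compound 3 to compound 4 (0.04 log units; within the scatter) and replacing phenyl with hydrogen does too at a 1.4-fold higher number from compound 2 to compound 4 (0.14 log units; within the scatter). Among the compounds shown here, only replacing 2-fluorophenyl with hydrogen passes the scatter, and modestly, at a 2.1-fold higher number from compound 1 to compound 4 (0.32 log units; beyond the scatter), so this position now shows a first step beyond the scatter. No supporting measurement accounts for that step.

As far as these compounds go, whether an amine, a carboxylic acid or a longer chain at this place would give a larger step remains open. So does the effect of fluoro elsewhere on the phenyl ring.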